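The compounds below may be only part of what the source reports. "The series", "measured", "known", "first", "only" and "open" are said of these compounds alone.

Compound 1 `CCCNc1nc(C)c(-c2nc3ccccc3s2)c(N[C@@H]2C[C@H](CO)[C@@H](O)[C@H]2O)n1`: in an ADME assay on cells (Homo sapiens) for cytotoxicity, read by polymerase chain reaction, with a stated time of 3 days (a higher number here means that more compound is tolerated, a lower number that less compound is tolerated), compound 1 gives > 25000 nM, which is a limit of the assay.
Compound 2 `Cc1nc(NCC2CCC2)nc(N[C@@H]2C[C@H](CO)[C@@H](O)[C@H]2O)c1-c1nc2ccccc2s1`: in this assay compound 2 gives > 25000 nM, again a limit of the assay.

Compound 2 thus stands at the limit and has no number of its own. Within the data shown here, the one further value shown, that of compound 1, is a limit too, so the limit of > 25000 nM in this assay, at which 2 of the 2 values shown sit, sums up everything the measurements give. Among the measured compounds shown here, the single measured step, a step that the two limits leave unreadable from compound 1 to compound 2, joins two limits and therefore cannot be read.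

Compound 3 `Cc1nc(NCCNS(C)(=O)=O)nc(N[C@@H]2C[C@H](CO)[C@@H](O)[C@H]2O)c1-c1nc2ccccc2s1` differs from compound 2 by (methanesulfonamido)methyl in place of cyclobutyl on a saturated chain carbon bound to a nitrogen on an aromatic ring. For the measured compounds named here, no measured step bears on this change in a readable way; the step from compound 1 to compound 2 shows only that a change of the chain on the same nitrogen left both ends at the limit. On that footing the step that the limit leaves unreadable from compound 2 to compound 3 is expected to be none beyond the scatter. Compound 3 is most likely to be reported as a limit once more. Compound 3 is accordingly estimated at 30000 nM in this assay, within a range of 12000 nM to 80000 nM.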

Compound 3, half-maximal cytotoxic concentration: > 25000 nM
Compound 3: no number, only a limit; the forecaster's own chance of this, stated with the estimate: 80%; the middle value does not contradict the limit.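

In this assay compound 3 gives > 25000 nM, which is a limit of the assay. None of the steps among compound 1, compound 2 and compound 3 can be read, as all three stand at the same limit: the limit of > 25000 nM in this assay, at which 3 of the 3 values shown sit.

The compounds shown leave open at what concentration any of them becomes cytotoxic, and whether the chain on the nitrogen alters that concentration.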